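The compounds below may be only part of what the source reports. "The series", "measured", "known", "first", "only" and "open" are said of these compounds alone.

The three compounds share one core, in which an aromatic ring carries a carbonyl linked to a small three-membered ring that in turn bears a chlorine-substituted aromatic ring; they differ only in what sits on the nitrogen attached to the first aromatic ring. Compound 1 `O=C(c1ccc(NC2CCCCC2)cc1)C1CC1c1ccc(Cl)cc1` carries a cyclohexyl group on that nitrogen, and in an ADME assay on Vero cells (Chlorocebus sabaeus) for cytotoxicity, with a stated time of 72 h (a lower number here means that less compound is tolerated, a higher number that more compound is tolerated), compound 1 gives 196 ug/mL. Compound 2 `CC(C)CCCC(C)Nc1ccc(C(=O)C2CC2c2ccc(Cl)cc2)cc1` carries a branched chain, the 1,5-dimethylhexyl group, on the same nitrogen; in this assay compound 2 gives "not determined" (no result reported), so no number stands for it and it offers no footing for comparison.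

Compound 3 `CCCCCCCCNc1ccc(C(=O)C2CC2c2ccc(Cl)cc2)cc1` is the next one to be tested in this assay. The change from compound 2 to compound 3 is octyl in place of 1,5-dimethylhexyl on a nitrogen on an aromatic ring. Within the data shown here, since compound 2 has no number, the size and direction of this step in this assay cannot be anchored; the only guide is compound 1 with its 196 ug/mL. Compound 3 is therefore expected to come out around 150 ug/mL, with a range from 50 ug/mL to 300 ug/mL.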

Compound 3, half-maximal cytotoxic concentration: 214 ug/mL
Compound 3: the middle estimate sits 1.4-fold (0.15 log units) below what was measured, and the stated range covers the measured number.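

Among these compounds, with octyl in place of cyclohexyl on a nitrogen on an aromatic ring, this assay gives a 1.1-fold higher number from compound 1 to compound 3 (0.04 log units; within the scatter) as the first readable comparison at this position, so in this pair the open chain and the ring on that nitrogen cannot be told apart in how much compound the cells tolerate. As far as these compounds go, compound 2 has no number, so the swap of 1,5-dimethylhexyl for octyl cannot be read, and what branching in the chain does to this number stays unknown. Nothing measured here offers an explanation for how closely compound 1 and compound 3 agree.

Among the compounds shown here, two numbers at one position are too few to establish a rule, and they show only that these two groups are not told apart, not that any group placed on this nitrogen would behave alike. The compounds shown leave open whether a much shorter chain such as butyl, a longer chain such as dodecyl, or a chain ending in an amine or a carboxylic acid would keep the number in the same region.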